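Lengthening the Aryl Ether Chain by One Carbon

A few compounds are considered here, and "the series" means these few. Any claim that something is new, unique, unknown or untested is made for them only; others in the source may bear on it.

Compound 3 `CCCCCCOc1ccc2c(c1)C(=O)NCCO2` gives 47.3 mg/kg in a functional assay on the whole organism with Mus musculus as the target, in the maximal electroshock model, with stated times of 30 min and 4 h (on this read-out higher numbers stand for an effect only at larger amounts of compound and lower numbers for an effect already at smaller amounts), the smallest of the three numbers, though not separated from the others beyond the scatter: compound 2 `CCCCCOc1ccc2c(c1)C(=O)NCCO2` gives 56.8 mg/kg and compound 1 `CCCOc1ccc2c(c1)C(=O)NCCO2` gives 78.3 mg/kg in this assay. Compound 4 `CCCCCCCOc1ccc2c(c1)C(=O)NCCO2` differs from compound 3 by methyl in place of hydrogen on a saturated chain carbon, six bonds along the chain from an oxygen on an aromatic ring. The measured steps along the same chain bear on this: a 1.4-fold lower number from compound 1 to compound 2 (0.14 log units; within the scatter), a 1.7-fold lower number from compound 1 to compound 3 (0.22 log units; within the scatter) and a 1.2-fold lower number from compound 2 to compound 3 (0.08 log units; within the scatter), each within the scatter and each pointing toward smaller numbers. The step from compound 3 to compound 4 is therefore expected to be at most a small lowering, a 1.2-fold lower number from compound 3 to compound 4 (0.07 log units; within the scatter), nothing beyond the scatter. Compound 4 is estimated at 40 mg/kg, with a range from 25 mg/kg to 65 mg/kg.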

Compound 4, dose for half-maximal effect: 19 mg/kg
Compound 4: middle estimate off by 2.1-fold (0.32 log units), on the high side, and the stated range ends above it.
By their numbers in this assay, from the lowest: compound 4; then compounds 3, 2 and 1 (each within the scatter of the next).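

In this assay, among the compounds shown here, methyl in place of hydrogen at this position, six bonds along the chain from an oxygen on an aromatic ring, gives a single-carbon step beyond the scatter (a 2.5-fold lower number from compound 3 to compound 4 (0.40 log units; beyond the scatter)), whereas the earlier steps all stayed within it. The heptyl ether of compound 4 is also separated from both shorter chains tested (a 3.0-fold lower number from compound 2 to compound 4 (0.48 log units; beyond the scatter); a 4.1-fold lower number from compound 1 to compound 4 (0.62 log units; beyond the scatter)), a separation that compound 1, compound 2 and compound 3 never showed among themselves. Nothing available accounts for this step. Going by these compounds, whether a longer chain lowers the number further, or an amine in place of the chain retains the effect, remains open.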